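The source may hold more compounds than are shown below. What is called first, only, known or untested is meant among the compounds shown, and "the series" means these compounds.

Measured so far in an ADME assay on Vero cells (Chlorocebus sabaeus) for cytotoxicity, read by resazurin assay, with a stated time of 72 h; on this read-out lower numbers stand for an effect already at smaller amounts and higher numbers for an effect only at larger amounts of compound:

- compound 1 `N#C[Se]C[C@H]1Cc2ccc(Oc3ccccc3)cc2O1` gives > 20 uM as a limit
- compound 2 `FC(F)(F)SCCOc1ccc(Oc2ccccc2)cc1` gives > 20 uM as a limit
- compound 3 `FC(F)(F)SCCOc1cccc(Oc2ccccc2)c1` gives > 20 uM as a limit

None of these three entries is an exact number, and the set as a whole shows the limit of > 20 uM in this assay, at which 3 of the 3 values shown sit, and nothing finer. As far as these compounds go, compound 2 stands at > 20 uM in this assay and this is a limit, so its true position on the scale remains open.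

The next compound to be tested is compound 4 `N#CCCOc1ccc(Oc2ccccc2)cc1` which keeps the rest of compound 2 and changes one group. The difference is cyano in place of (trifluoromethyl)sulfanyl on a saturated chain carbon, two bonds along the chain from an oxygen on an aromatic ring and in words it is cyano in place of (trifluoromethyl)sulfanyl on a saturated chain carbon, two bonds along the chain from an oxygen on an aromatic ring.

Among the compounds with values here, no measured pair in this small set shows what a swap of this kind does. The expectation therefore leans on the limit of compound 2 at > 20 uM and on the matching limits of the other two compounds. The expected change, a number no higher from compound 2 to compound 4 (the limit leaves the size open) in size, is none beyond the usual scatter, and a further limit is the most likely report. For compound 4 the estimate is 20 uM with an expected range from 10 uM to 40 uM in this test.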

Compound 4, concentration for half-maximal effect: > 20 uM
Compound 4: no number, only a limit (the forecaster's own chance of this, stated with the estimate: 75%); the middle value lies on the limit itself.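

No step can be read from compound 2 to compound 4, because each gives only a limit and no exact number: the limit of > 20 uM in this assay, at which 4 of the 4 values shown sit.

The compounds shown leave open where any of them truly stands in this assay, and whether cyano in place of (trifluoromethyl)sulfanyl on this chain changes the result at all.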